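Amide-nitrogen substituents in the antiproliferative series

The compounds below may be only part of what the source reports. "The series", "measured", "known", "first", "only" and "open" are said of these compounds alone.

Measured in a functional assay on MCF7 cells (Homo sapiens) for antiproliferative activity, read by MTT assay, with a stated time of 48 h (a higher number here means a weaker inhibitor, a lower number a stronger inhibitor), so far:
- compound 1 `CCn1c(C(=O)NCCN(C)C)ccc1C(CC)(CC)c1ccc(OCCC(O)(CC)CC)c(C)c1` gives 430 nM
- compound 2 `CCn1c(C(=O)Nc2ccc(OC(F)(F)F)cc2)ccc1C(CC)(CC)c1ccc(OCCC(O)(CC)CC)c(C)c1` gives > 50000 nM as a limit of the assay
- compound 3 `CCn1c(C(=O)NC(CC(=O)O)C(=O)OC)ccc1C(CC)(CC)c1ccc(OCCC(O)(CC)CC)c(C)c1` gives 10200 nM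

Of the two numeric values, compound 3 holds the higher at 10200 nM and no closer neighbour than compound 1 is available. Compound 2 stands only as a limit of the assay.

Compound 4 `CCn1c(C(=O)NC(CO)CCO)ccc1C(CC)(CC)c1ccc(OCCC(O)(CC)CC)c(C)c1` carries a group of 6 heavy atoms (4 carbon, 2 oxygen; no ring) in place of a group of 9 heavy atoms (5 carbon, 4 oxygen; no ring), on an amide-type nitrogen and the entering 3-hydroxy-1-(hydroxymethyl)propyl has no ring and no net charge. All measured steps fall on this same amide-type nitrogen. Two are large, an at least 110-fold higher number from compound 1 to compound 2 (2.06 log units; beyond the scatter) and a 24-fold higher number from compound 1 to compound 3 (1.38 log units; beyond the scatter), and an at least 4.9-fold lower number from compound 2 to compound 3 (0.69 log units; beyond the scatter) is at least modest. None of them makes this exact change, so they argue for a wide range more than for a direction. Compound 4 is read against compound 3 at 10200 nM in this assay since both groups hold only carbon and oxygen. The estimated step is a 1.3-fold lower number from compound 3 to compound 4 (0.11 log units; within the scatter) and so none beyond the scatter is expected. For compound 4 the estimate is 8000 nM with 2000 nM to 30000 nM as the expected range.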

Compound 4, half-maximal inhibitory concentration: 31400 nM
Beside the measured number, compound 4's estimate is 3.9-fold (0.59 log units) below it, outside the stated range (above it).
By their numbers in this assay, from the lowest: compound 1; then compound 3; then compound 4. At a limit, above all of these: compound 2.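

Even among groups holding only carbon and oxygen, with no ring and no net charge, this amide-type nitrogen discriminates in this assay: 3-hydroxy-1-(hydroxymethyl)propyl in place of the group of 9 heavy atoms (5 carbon, 4 oxygen; no ring) gives a modest step, a 3.1-fold higher number from compound 3 to compound 4 (0.49 log units; beyond the scatter). The same group does not approach the 2-(dimethylamino)ethyl of compound 1, with a 73-fold higher number from compound 1 to compound 4 (1.86 log units; beyond the scatter), so that group keeps the lowest number in the series. Compound 2 stands only as a limit: the limit of > 50000 nM in this assay, at which 1 of the 4 values shown sits. Read from that limit, the step is an at least 1.5-fold lower number from compound 2 to compound 4 (0.20 log units; that floor lies within the scatter), which gives only a floor.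

Which part of the group in compound 3, the carboxylic acid or the methyl ester, goes with its position relative to compound 4 stays open. So does whether the low number of compound 1 follows the tertiary amine or its chain length, a question that 3-(dimethylamino)propyl or 2-(morpholin-4-yl)ethyl on the same nitrogen would address.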